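Ester to Amide on a Carbamate Scaffold

A few compounds are considered here, and "the series" means these few. Any claim that something is new, unique, unknown or untested is made for them only; others in the source may bear on it.

Measured so far:
- compound 1, `CCOC(=O)c1cc(-c2ccc(OC(=O)NC3CCCCC3)cc2)n(-c2ccccc2)n1`: 268 nM
- compound 2, `CCOC(=O)c1cc(-c2ccc(OC(=O)NC3CCCCC3)cc2)n(-c2ccc(Cl)cc2)n1`: 281 nM

Both compounds were tested in an assay on isolated protein for inhibition of Fatty-acid amide hydrolase 1 (Homo sapiens), read by fluorescence, with a stated time of 30 min; a lower number here means a stronger inhibitor, a higher number a weaker inhibitor. For the measured compounds named here, compound 1 gives 268 nM and compound 2 gives 281 nM; the two numbers lie within the scatter of each other, and the one recorded step, a 1.0-fold higher number from compound 1 to compound 2 (0.02 log units; within the scatter), says only that a chloro in place of hydrogen on the second aromatic ring changes nothing that can be read.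

Compound 3, `NC(=O)c1cc(-c2ccc(OC(=O)NC3CCCCC3)cc2)n(-c2ccccc2)n1`, has not yet been measured. It differs from compound 1 in a different place: amino in place of ethoxy on a carbonyl carbon. Going by the values given here, no measured step touches the ester group, so there is nothing among the two numbers that directly foretells the effect of turning it into a primary amide; the step from compound 1 to compound 2 concerns another part of the molecule.

Without a guiding step, the expectation has to be cautious. The estimate is a modest shift, a 1.7-fold higher number from compound 1 to compound 3 (0.23 log units; within the scatter), which is close to the scatter. Compound 3 is therefore expected to give about 450 nM, with a plausible range from 120 nM to 2000 nM.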

Compound 3, half-maximal inhibitory concentration: 71 nM
Estimate against measurement, compound 3: 6.3-fold (0.80 log units) above, outside the stated range (below it).
By their numbers in this assay, from the lowest: compound 3; then compounds 1 and 2 (each within the scatter of the next).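

In this assay, the group on the carbonyl carbon proves to be a place where a single change can be read: putting amino in place of ethoxy gives a 3.8-fold lower number from compound 1 to compound 3 (0.58 log units; beyond the scatter) and so turns the ester into a primary amide. For the compounds shown here, this is a modest step, but it lies beyond the scatter, unlike the only earlier step, and it shows that the ethoxycarbonyl group is not needed to reach a number at this level, since carbamoyl, with a hydrogen-bond donor where ethoxy brought an acceptor, does at least as well in this pair. Nothing shown here explains the drop, so it stands as an observation without a known cause.

The compounds shown leave open how methylamino or dimethylamino on this carbonyl carbon would read, or a carboxylic acid there, and so whether the result depends on amino itself or simply on the loss of ethoxy. They also leave open whether chloro in place of hydrogen, which gave a 1.0-fold higher number from compound 1 to compound 2 (0.02 log units; within the scatter) in the ester series, would stay just as unreadable in a compound carrying carbamoyl.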